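The compounds below may be only part of what the source reports. "The series", "measured", "known", "first", "only" and "open" are said of these compounds alone.

Within the data shown here, in a functional assay on HT-29 cells (Homo sapiens) for cytotoxicity, read by MTT assay, with a stated time of 72 h (on this read-out lower numbers stand for stronger inhibition and higher numbers for weaker inhibition), compound 3 `O=C(CN1CCN(c2nnc(Cc3ccncc3)c3ccccc23)CC1)Nc1ccc(F)c(Cl)c1` gives 880 nM, the lowest of the three numbers so far. Compound 1 `O=C(CN1CCN(c2nnc(Cc3ccccc3)c3ccccc23)CC1)Nc1c(F)cccc1F` gives 19700 nM and compound 2 `Cc1ccccc1NC(=O)CN1CCN(c2nnc(Cc3ccccc3)c3ccccc23)CC1` gives 113000 nM. Compound 4 `O=C(CN1CCN(c2nnc(Cc3ccccc3)c3ccccc23)CC1)Nc1ccc(F)c(Cl)c1` departs from compound 3 by phenyl in place of pyridin-4-yl on a saturated chain carbon bound to an aromatic carbon. Among the measured compounds shown here, the only measured step, a 5.7-fold higher number from compound 1 to compound 2 (0.76 log units; beyond the scatter), lies on an amide-type nitrogen and does not test this change. Compounds 1 and 2 carry phenyl at this place, but they also differ from compound 3 on that nitrogen, so they offer only indirect support. A clear rise is therefore expected, estimated as an 8.0-fold higher number from compound 3 to compound 4 (0.90 log units; beyond the scatter). Compound 4 is expected at 7000 nM, with an estimated range from 1800 nM to 30000 nM.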

Compound 4, half-maximal inhibitory concentration: 13300 nM
Estimate against measurement, compound 4: 1.9-fold (0.28 log units) below; the range from low to high includes it.
By their numbers in this assay, from the lowest: compound 3; then compounds 4 and 1 (each within the scatter of the next); then compound 2.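

In this assay, among these compounds, a 15-fold higher number from compound 3 to compound 4 (1.18 log units; beyond the scatter) gives the first direct reading of this place: with 3-chloro-4-fluorophenyl held on the amide-type nitrogen, phenyl in place of pyridin-4-yl gives a large rise. With phenyl at this place, the amide-type nitrogen also separates its groups unevenly: an 8.5-fold lower number from compound 2 to compound 4 (0.93 log units; beyond the scatter) sets 3-chloro-4-fluorophenyl apart from 2-methylphenyl, whereas a 1.5-fold lower number from compound 1 to compound 4 (0.17 log units; within the scatter) does not separate it from 2,6-difluorophenyl. Going by these compounds, whether pyridin-3-yl or pyridin-2-yl would match pyridin-4-yl at this place stays open. Nothing shown here explains the size of this step.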